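Swapping Methyl for Chloro: an Estimate for Compound 4

This account rests on a few compounds, and the source may have more. Where it says the series, first, only, none or still open, it means among the compounds named here.

The study compares four compounds carrying a substituted phenyl ring on a shared type of core, tested in a functional assay on DU-145 cells (Homo sapiens) for cytotoxicity, read by MTT assay, with a stated time of 48 h; a higher number here means a weaker inhibitor, a lower number a stronger inhibitor. Compound 1 `CCOC(=O)c1c(-c2c(Cl)c3ccccc3oc2=O)nn(-c2cccc(C)c2)c1C(=O)OCC` gives 32000 nM. Compound 2 `CCOC(=O)c1c(-c2c(Cl)c3ccccc3oc2=O)nn(-c2cccc(Cl)c2)c1C(=O)OCC` differs from compound 1 by chloro in place of methyl on an aromatic carbon. In this assay compound 2 gives 24000 nM. The resulting step of a 1.3-fold lower number from compound 1 to compound 2 (0.12 log units; within the scatter) is small. Compound 3 `COC(=O)c1c(-c2cc3ccccc3oc2=O)nn(-c2cccc(C)c2)c1C(=O)OC` rests on a different core; the difference between the core of compound 3 and the core of compound 1 is not broken down here. In this assay compound 3 gives 35000 nM, a number within the scatter of the values of compound 1 and compound 2.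

Compound 4 `COC(=O)c1c(-c2cc3ccccc3oc2=O)nn(-c2cccc(Cl)c2)c1C(=O)OC` has not yet been measured. It differs from compound 3 by chloro in place of methyl on an aromatic carbon, the same change that carries compound 1 to compound 2; this change occurs twice among these compounds. Because a 1.3-fold lower number from compound 1 to compound 2 (0.12 log units; within the scatter) lay within the scatter, compound 4 is expected to stay close to compound 3, with an expected step of a 1.3-fold lower number from compound 3 to compound 4 (0.10 log units; within the scatter). Compound 4 is therefore estimated at 28000 nM, with a likely range from 15000 nM to 55000 nM.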

Compound 4, half-maximal inhibitory concentration: 32000 nM
For compound 4 the middle estimate is 1.1-fold (0.06 log units) below the measured one, and the stated range covers the measured number.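

In this assay, replacing 3-methylphenyl with 3-chlorophenyl on the core of compound 3 gives a small step, a 1.1-fold lower number from compound 3 to compound 4 (0.04 log units; within the scatter), so the change leaves the number where it stood on this core as well. Set beside the earlier step, the change carries over from one core to the other without a detectable difference: the same change on two cores in this assay, a 1.3-fold lower number (0.12 log units; within the scatter) from compound 1 to compound 2 and a 1.1-fold lower number (0.04 log units; within the scatter) from compound 3 to compound 4, 1.2-fold (0.09 log units) apart, within the scatter of two such steps. For the compounds shown here, this shows only that on these two cores the swap stays within the scatter; with both steps that small, it shows neither that chloro differs from methyl in any real way nor that the change would behave alike on other cores.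

The compounds shown carry only methyl and chloro at this place on the phenyl ring, so it remains open whether an amine, a carboxylic acid or a longer chain there would move the number beyond the scatter. Whether any group at this place can shift the number at all is therefore also left open.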